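A Sulfamoylphenyl Swap in a Series Stuck at the Limit

The compounds below may be only part of what the source reports. "The series", "measured", "known", "first", "only" and "open" are said of these compounds alone.

Three compounds share one core and differ only in the group attached to an aromatic nitrogen. Compound 1 `Cc1ccccc1-n1nncc1CN1C(=O)C2(C(C#N)=C(N)Oc3c2c2nc4ccccc4nc2c2ccccc32)c2ccccc21` carries a 2-methylphenyl there, compound 2 `N#CC1=C(N)Oc2c(c3nc4ccccc4nc3c3ccccc23)C12C(=O)N(Cc1cnnn1-c1ccccc1Br)c1ccccc12` a 2-bromophenyl, and compound 3 `COc1ccc(-n2nncc2CN2C(=O)C3(C(C#N)=C(N)Oc4c3c3nc5ccccc5nc3c3ccccc43)c3ccccc32)cc1` a 4-methoxyphenyl. In a functional assay on HepG2 cells (Homo sapiens) for antiproliferative activity, read by MTT assay, with a stated time of 48 h (on this read-out higher numbers stand for weaker inhibition and lower numbers for stronger inhibition), compound 1 gives a value that is only a limit of the assay, > 50000 nM. Compound 2 likewise reaches only a limit, > 50000 nM. Compound 3 also stops at a limit, > 50000 nM. Because every value sits at the limit of > 50000 nM in this assay, at which 3 of the 3 values shown sit, none of the steps among them can be sized: a step that the two limits leave unreadable from compound 1 to compound 2, a step that the two limits leave unreadable from compound 1 to compound 3 and a step that the two limits leave unreadable from compound 2 to compound 3 all remain unreadable. Compound 2 therefore stands at the limit, indistinguishable on the numbers from its two neighbours.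

Compound 4 `N#CC1=C(N)Oc2c(c3nc4ccccc4nc3c3ccccc23)C12C(=O)N(Cc1cnnn1-c1ccc(S(N)(=O)=O)cc1)c1ccccc12` is the next member. 4-sulfamoylphenyl in place of 2-bromophenyl on an aromatic nitrogen The steps measured so far bear on this change only in that all of them stayed at the limit; they give no size and no direction. Compound 4 is thus expected to stay at the limit as well, with an estimated step of a number no higher from compound 2 to compound 4 (the limit leaves the size open) that amounts to nothing readable. Compound 4 is estimated at 50000 nM in this assay, with a range from 15000 nM to 200000 nM.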

Compound 4, half-maximal inhibitory concentration: 42200 nM
Estimate against measurement, compound 4: 1.2-fold (0.07 log units) above; low and high end bracket the measured number.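

In this assay compound 4 is the only one of the four shown that gives a number rather than a limit, 42200 nM. The change to 4-sulfamoylphenyl on the aromatic nitrogen gives an at least 1.1-fold lower number from compound 2 to compound 4 (0.07 log units; that floor lies within the scatter), and the same comparison gives an at least 1.1-fold lower number from compound 1 to compound 4 (0.07 log units; that floor lies within the scatter), while sulfamoyl in place of methoxy on the aromatic carbon gives an at least 1.1-fold lower number from compound 3 to compound 4 (0.07 log units; that floor lies within the scatter). Each of these is only a floor, so this position is now shown to admit a group that yields a readable number, but no gain beyond the scatter is shown, and the steps among the other three compounds still cannot be read: the limit of > 50000 nM in this assay, at which 3 of the 4 values shown sit.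

As far as these compounds go, how far compound 1, compound 2 and compound 3 lie past their limit stays open, and with it the true size of all three steps to compound 4. Also open, from the compounds shown here alone, is whether the sulfamoyl group itself matters here, or whether 4-carboxyphenyl or 4-aminophenyl on the same aromatic nitrogen would give a number that clearly parts from the limit.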